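A few compounds are considered here, and "the series" means these few. Any claim that something is new, unique, unknown or untested is made for them only; others in the source may bear on it.

compound 1 `CCOC(=O)c1c(-c2ccccc2)c(OC(C)=O)c2ccccc2c1OC`: 5810 nM
compound 2 `CCOC(=O)c1c(CC)c(OC)c2ccccc2c1OC(C)=O`: 3760 nM
compound 3 `CCCCCc1c(C(=O)OCC)c(OC(C)=O)c2ccccc2c1OC`: 8920 nM

All three were tested in a functional assay for inhibition, with Rattus norvegicus as the target; on this read-out higher numbers stand for weaker inhibition and lower numbers for stronger inhibition. There, compound 2 gives 3760 nM and compound 1 gives 5810 nM, two values within the usual scatter of each other, so the pair cannot be ranked. Going by the values given here, the one clear gap from compound 2 is a 2.4-fold higher number from compound 2 to compound 3 (0.38 log units; beyond the scatter). In that step, propyl takes the place of hydrogen on a saturated chain carbon, two bonds along the chain from an aromatic carbon.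

The next compound to be tested is compound 4 `CCCCc1c(CC)c(OC)c2ccccc2c1OC(C)=O`. Here butyl replaces ethoxycarbonyl on an aromatic carbon: butyl in place of ethoxycarbonyl on an aromatic carbon.

Among the compounds with values here, all three measured compounds carry the ethoxycarbonyl group, so no measured step shows directly what happens when it leaves. Within the data shown here, the nearest guide is a 2.4-fold higher number from compound 2 to compound 3 (0.38 log units; beyond the scatter), the only measured step that adds saturated chain, though it does so at another place and keeps the ethoxycarbonyl group. That single modest step gives weak support for a move of similar size towards a higher number in this assay, with wide uncertainty in both directions. The expected change is a 2.0-fold higher number from compound 2 to compound 4 (0.30 log units; within the scatter). For compound 4 the estimated value is 7500 nM. The expected range for compound 4 runs from 2000 nM to 28000 nM.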

Compound 4, half-maximal inhibitory concentration: 990 nM
Beside the measured number, compound 4's estimate is 7.6-fold (0.88 log units) above it, and the stated range ends above it.
By their numbers in this assay, from the lowest: compound 4; then compounds 2, 1 and 3 (each within the scatter of the next, the first and the last beyond it).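

In this assay, replacing the ethoxycarbonyl group on this aromatic carbon with butyl gives a 3.8-fold lower number from compound 2 to compound 4 (0.58 log units; beyond the scatter) and so moves towards stronger inhibition, which shows that this group is not needed here for inhibition at this level. Going by these compounds alone, all the earlier compounds carried ethoxycarbonyl, so they could not show this, and the swap also shows that a compound with no hydrogen-bond acceptors in the group at this place can still give the lowest number of the four. Added saturated chain does not act the same way everywhere on the shared core, since the other chain step, a 2.4-fold higher number from compound 2 to compound 3 (0.38 log units; beyond the scatter) and a move towards weaker inhibition, runs in the opposite direction, and nothing available here explains the difference.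

Going by these compounds, this single swap cannot separate the effect of losing ethoxycarbonyl from the effect of gaining butyl, so it remains open how a longer chain such as hexyl or a carboxylic acid would read at this aromatic carbon. On these data alone, it also remains open whether the same swap would lower the number on the core of compound 1, which carries a phenyl group in place of the ethyl group.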